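A few compounds are considered here, and "the series" means these few. Any claim that something is new, unique, unknown or untested is made for them only; others in the source may bear on it.

Compound 1 `CN1C(=O)[C@@]2(c3ccccc31)N(C)C[C@@H](c1ccco1)[C@@]21Cc2ccccc2C1=O` gives 8.2% in a functional assay on the whole organism (strain Wister albino) for inhibition, with Rattus norvegicus as the target, read by paw edema, with stated times of 1 h and 4 h, at a dose of 50 mg/kg by the intraperitoneal route; a lower number here means less inhibition, a higher number more inhibition at the dose given (going by the name of the read-out). Compound 2 `Cc1ccc([C@@H]2CN(C)[C@]3(C(=O)N(C)c4ccccc43)[C@]23Cc2ccccc2C3=O)cc1` gives 13.9%. Compound 3 `CN1C(=O)[C@@]2(c3ccccc31)N(C)C[C@@H](c1cccs1)[C@@]21Cc2ccccc2C1=O` gives 12.9%.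

Compound 3 holds the second highest of the three numbers, yet all three sit within the scatter of one another: its nearest neighbour is compound 2, a number 1 percentage points lower from compound 2 to compound 3 (within the scatter), and the furthest is compound 1, a number 4.7 percentage points higher from compound 1 to compound 3 (within the scatter). Compound 4 `COc1ccc([C@@H]2CN(C)[C@]3(C(=O)N(C)c4ccccc43)[C@]23Cc2ccccc2C3=O)cc1` differs from compound 3 in one place: 4-methoxyphenyl in place of thiophen-2-yl on a saturated ring carbon. Among the measured compounds shown here, the steps that bear on this exchange of the aryl group are a number 5.7 percentage points higher from compound 1 to compound 2 (within the scatter) and a number 1 percentage points lower from compound 2 to compound 3 (within the scatter), both within the scatter, so no shift beyond the scatter is expected, a number 0.9 percentage points lower from compound 3 to compound 4 (within the scatter). Compound 4 is therefore estimated at 12%, with a range from 4% to 22%.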

Compound 4, a percentage reported as inhibition, in the whole organism at one dose (the size of the read-out at that dose, not a potency): 3.8%
The estimate for compound 4 lay 8.2 percentage points above the measured number, and the stated range ends above it.
By their numbers in this assay, from the lowest: compounds 4, 1, 3 and 2 (each within the scatter of the next, the first and the last beyond it).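

In this assay, among the compounds shown here, the exchange on the aromatic carbon of the para-free wording aside, methoxy in place of methyl gives the only step here beyond the scatter (a number 10.1 percentage points lower from compound 2 to compound 4 (beyond the scatter)), and it is a modest one. For the compounds shown here, the exchanges of thiophen-2-yl and furan-2-yl for 4-methoxyphenyl on the saturated ring carbon stay within the scatter (a number 9.1 percentage points lower from compound 3 to compound 4 (within the scatter) and a number 4.4 percentage points lower from compound 1 to compound 4 (within the scatter)), so only this small change within the aryl group separates two compounds at this position. Nothing available accounts for that step. The compounds shown leave open whether an amine, a carboxylic acid or a longer chain such as butoxy on that aromatic carbon would move the number further.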